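Swapping a Dichlorophenyl for a Trifluoromethylphenyl Urea Tail

This account rests on a few compounds, and the source may have more. Where it says the series, first, only, none or still open, it means among the compounds named here.

The measured compounds and their values:

Compound 1 `O=C(Nc1cccc(-n2cc(-c3ccncc3)c(-c3ccc(Cl)c(O)c3)n2)c1)Nc1ccc(Cl)c(Cl)c1` in a functional assay on 786-0 cells (Homo sapiens) for inhibition, read by sulforhodamine B assay, with a stated time of 48 h (a lower number here means that less compound is tolerated, a higher number that more compound is tolerated), gives > 32500 nM, which is a limit of this assay and not a number.
Compound 2 `COc1cc(-c2nn(-c3cccc(NC(=O)c4ccc(Cl)c(C(F)(F)F)c4)c3)cc2-c2ccncc2)ccc1Cl` in this assay gives > 32500 nM, again a limit.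
Compound 3 `COc1cc(-c2nn(-c3cccc(NC(=O)c4ccccc4)c3)cc2-c2ccncc2)ccc1Cl` in this assay gives > 100000 nM, also a limit.

None of the three compounds therefore has a readable number; compound 1 sits at the limit of > 32500 nM in this assay, at which 2 of the 3 values shown sit, while compound 3 sits at the limit of > 100000 nM in this assay, at which 1 of the 3 values shown sits. For the measured compounds named here, the one step between measured compounds that share all but one place is a step that the two limits leave unreadable from compound 2 to compound 3, and it cannot be sized. Compound 4 `O=C(Nc1cccc(-n2cc(-c3ccncc3)c(-c3ccc(Cl)c(O)c3)n2)c1)Nc1cccc(C(F)(F)F)c1` differs from compound 1 by 3-(trifluoromethyl)phenyl in place of 3,4-dichlorophenyl on an amide-type nitrogen. No measured step touches this amide-type nitrogen, so the only guide is that every compound shown tolerates at least the amounts given by its limit. The step from compound 1 to compound 4 is expected to be a step that the limit leaves unreadable from compound 1 to compound 4, that is, none beyond the scatter. Compound 4 is accordingly estimated at 50000 nM, within a range from 20000 nM to 150000 nM, with a limit rather than a number the more likely outcome.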

Compound 4, concentration lethal to 50% of the cells: > 32500 nM
Compound 4: only a limit was reported; the forecaster's own chance of this, stated with the estimate: 80%; the middle value is on the limit's open side.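

Compound 4 gives > 32500 nM in this assay, which is a limit and not a number. For the compounds shown here, compound 1 also has only a limit, so no step between compound 1 and compound 4 can be read. Still open is what actual number any compound shown would give, and whether 3-(trifluoromethyl)phenyl and 3,4-dichlorophenyl differ at all.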